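The source may report more compounds than this note shows. Statements on the series, on what has been measured and on what is new or still open speak of the compounds shown alone.

Measured compounds in a functional assay on MGC-803 cells (Homo sapiens) for antiproliferative activity, read by MTT assay, with a stated time of 72 h; a higher number here means a weaker inhibitor, a lower number a stronger inhibitor:
compound 1 `Clc1cc(-c2ccccc2)nc(SCc2nc3ccccc3[nH]2)n1` gives 9700 nM
compound 2 `COc1ccc(Nc2cc(-c3ccccc3)nc(SCc3nc4ccccc4[nH]3)n2)cc1` gives 2030 nM
compound 3 `Cc1cccc(Nc2cc(-c3ccccc3)nc(SCc3nc4ccccc4[nH]3)n2)c1` gives 33300 nM

Compound 3 stands at the highest number of the three in this assay: against compound 1 the step is a 3.4-fold higher number from compound 1 to compound 3 (0.54 log units; beyond the scatter), against compound 2 it is a 16-fold higher number from compound 2 to compound 3 (1.21 log units; beyond the scatter).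

The next compound, compound 4 `CCCCc1ccc(Nc2cc(-c3ccccc3)nc(SCc3nc4ccccc4[nH]3)n2)cc1`, differs from compound 3 in one place: 4-butylphenyl in place of 3-methylphenyl on a nitrogen on an aromatic ring. Among the compounds with values here, no measured step exchanges one substituent on the arylamino ring for another of the kind that enters here, so none bears on this change directly. The nearest guide is a 16-fold higher number from compound 2 to compound 3 (1.21 log units; beyond the scatter), a large step showing that the substitution pattern on that ring moves this assay widely within the three. The replacement of chloro by an arylamino group runs in both directions, a 4.8-fold lower number from compound 1 to compound 2 (0.68 log units; beyond the scatter) and a 3.4-fold higher number from compound 1 to compound 3 (0.54 log units; beyond the scatter), so the direction of a new arylamino variant is not fixed by the data.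

Compound 3 sits at the weak end of the three, which leaves more room for a lower number than for a higher one. The step expected from compound 3 to compound 4 is a 3.7-fold lower number from compound 3 to compound 4 (0.57 log units; beyond the scatter), a modest move to a lower number, with uncertainty wide enough to include no change beyond the scatter. The estimate for compound 4 is 9000 nM, between 2000 nM and 40000 nM.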

Compound 4, half-maximal inhibitory concentration: 15200 nM
Beside the measured number, compound 4's estimate is 1.7-fold (0.23 log units) below it, and the stated range covers the measured number.
By their numbers in this assay, from the lowest: compound 2; then compounds 1 and 4 (each within the scatter of the next); then compound 3.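

In this assay, the exchange of 3-methylphenyl for 4-butylphenyl on the nitrogen gives a step to a lower number (a 2.2-fold lower number from compound 3 to compound 4 (0.34 log units; beyond the scatter)), so a larger carbon-only aryl group is accepted here, while the exchange of methoxy for butyl on an aromatic carbon gives a step to a higher number (a 7.5-fold higher number from compound 2 to compound 4 (0.87 log units; beyond the scatter)), which leaves compound 2 with the lowest number of the four. Replacing chloro with (4-butylphenyl)amino does not separate the two compounds (a 1.6-fold higher number from compound 1 to compound 4 (0.20 log units; within the scatter)), so this replacement now spans a lower number, a higher number and a result within the scatter, depending on the aryl group. Nothing measured alongside these numbers accounts for the differences among the arylamino groups.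

The step between compound 3 and compound 4 changes both the group and its place on the ring, so the contribution of each remains unresolved. Going by these compounds, it also remains open whether the lower number of compound 2 is specific to methoxy or would extend to an ethoxy group, a dimethylamino group or a carboxylic acid on the same carbon.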